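Fluoro to Trifluoromethyl on the Benzyl Amide

The source may hold more compounds than are shown below. What is called first, only, known or untested is meant among the compounds shown, and "the series" means these compounds.

Measured so far:
compound 1 `CCN(Cc1ccccc1)C(=O)C1CCN(S(=O)(=O)c2c(C)noc2C)CC1` — "not determined" (no result reported)
compound 2 `CCN(Cc1ccccc1)C(=O)C1CCN(S(=O)(=O)c2cccnc2)CC1` — "not determined" (no result reported)
compound 3 `CCN(Cc1ccccc1F)C(=O)C1CCN(S(=O)(=O)c2ccc3cn[nH]c3c2)CC1` — 84%

Three compounds share a piperidine amide core with a sulfonyl group on the ring nitrogen. In a functional assay on CHO cells for positive allosteric modulation of muscarinic acetylcholine receptor M5 (Homo sapiens), read by calcium flux (on this read-out lower numbers stand for smaller maximal responses and higher numbers for larger maximal responses), compound 1 gives "not determined" (no result reported) and compound 2 gives "not determined" (no result reported), so neither offers a number to compare. Compound 3 stands alone with a number: in this assay compound 3 gives 84%, the only measured maximal response in this set.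

Compound 4 `CCN(Cc1ccccc1C(F)(F)F)C(=O)C1CCN(S(=O)(=O)c2ccc3cn[nH]c3c2)CC1` has not yet been measured. It differs from compound 3 in one place: trifluoromethyl in place of fluoro on an aromatic carbon. For the measured compounds named here, no pair of measured compounds shows what this kind of change does here, so there is no step to lean on.

Going by the values given here, with only one number available, the expectation for compound 4 is that the step from compound 3 is small, in either direction, and within the scatter: a number 4 percentage points lower from compound 3 to compound 4 (within the scatter). In this assay compound 4 is expected to give about 80%, with a likely range from 55% to 100%.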

Compound 4, largest response reached (reported as percent of maximum), in percent of the reference or control that the assay uses: 92%
Estimate against measurement, compound 4: 12 percentage points below; the measured number falls inside the stated range.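

In this assay, for the compounds shown here, the change from 2-fluorobenzyl to 2-(trifluoromethyl)benzyl gives the first readable step at this position, a number 8 percentage points higher from compound 3 to compound 4 (within the scatter). The position therefore takes trifluoromethyl, with 4 heavy atoms against 1 for fluoro, while the maximal responses of the two compounds remain indistinguishable, so this pair does not separate the two groups. Nothing shown gives a measured explanation for this result.

Going by these compounds, the unsubstituted benzyl amide appears only in compound 1 and compound 2, which differ from compound 3 in more than one place and carry no number, so what either group contributes over hydrogen remains open. Also unresolved is how this position would respond to a different kind of group, such as an amine, a carboxylic acid or a methoxy group.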